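This account rests on a few compounds, and the source may have more. Where it says the series, first, only, none or still open, it means among the compounds named here.

Working notes on the imine series.

The series is measured in a functional assay on CCRF-CEM cells (Homo sapiens) for cytotoxicity; a lower number here means that less compound is tolerated, a higher number that more compound is tolerated. Compound 1, `C/C(=N\c1nc(NC2CC2)c2ncn(C3C=CC(CO)C3)c2n1)c1ccc(O)cc1`, gives 62000 nM in this assay. Compound 2, `COc1ccc(/C=N/c2nc(NC3CC3)c3ncn(C4C=CC(CO)C4)c3n2)c(O)c1`, gives 100000 nM in this assay. For the measured compounds named here, on the numbers so far compound 2 stands at the top of the two, but the gap to compound 1 is within the usual scatter, so the two are not told apart by this assay.

The next compound, compound 3, `Cc1ccc(/C=N/c2nc(NC3CC3)c3ncn(C4C=CC(CO)C4)c3n2)cc1`, differs from compound 2 at one place: 4-methylphenyl in place of 2-hydroxy-4-methoxyphenyl on a carbon with a double bond to nitrogen. Going by the values given here, no step between two measured compounds of this kind is known here, so the size of the change cannot be read from the measured pair; compound 1 and compound 2 differ at the same carbon in another way and sit within scatter of each other.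

The expectation is therefore a step of no size beyond the scatter, a 1.3-fold lower number from compound 2 to compound 3 (0.10 log units; within the scatter), in this assay. Compound 3 is estimated at 80000 nM in this assay, with a range from 30000 nM to 200000 nM, and the value may come back only as a limit.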

Compound 3, half-maximal cytotoxic concentration: > 100000 nM
Compound 3 was reported as a limit; the forecaster's own chance of this, stated with the estimate: 35%; middle value at least 1.2-fold (0.09 log units) from the limit.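

In this assay compound 3 stands as a limit and not as a number, > 100000 nM. For the compounds shown here, this gives the first reading at the carbon with a double bond to nitrogen: 4-methylphenyl in place of 2-hydroxy-4-methoxyphenyl, with the hydrogen-bond donor and acceptors of the leaving group gone, gives a number no lower from compound 2 to compound 3 (the limit leaves the size open), but the size of this step cannot be read because the reading stops at the limit: the limit of > 100000 nM in this assay, at which 1 of the 3 values shown sits. The other step that the result adds is an at least 1.6-fold higher number from compound 1 to compound 3 (0.20 log units; that floor lies within the scatter), so the floor of this step does not separate compound 3 from compound 1, and a true difference between the two can be neither claimed nor excluded.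

Left open is how far above the limit compound 3 lies, and so whether the exchange of the two aryl groups matters at all in this assay. Also open, on these data alone, is whether any other group at this carbon, such as an amine on the phenyl ring or a carboxylic acid in place of the methyl of 4-methylphenyl, would bring the number down beyond the scatter.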